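The source may report more compounds than this note shows. Statements on the series, on what has been measured and on what is new or still open speak of the compounds shown alone.

Measured so far:
compound 1 `ClCc1cccc(Cn2cnc3c(Cl)nc(Cl)nc32)c1` — 2390 nM
compound 2 `ClCc1cccc(Cn2cnc3nc(Cl)nc(Cl)c32)c1` — 950 nM
compound 3 `ClCc1ccccc1Cn1cnc2nc(Cl)nc(Cl)c21` — 190 nM

All three were tested in a functional assay on HCT-15 cells (Homo sapiens) for cytotoxicity, read by sulforhodamine B assay, with a stated time of 48 h; a lower number here means a stronger inhibitor of growth, a higher number a weaker inhibitor of growth. Among them compound 1 has the highest number, that is the weakest growth inhibition: compound 2 gives a lower number and compound 3 a lower one still, both gaps lying beyond the usual scatter. Compound 4 `Nc1nc(Cl)c2ncn(Cc3cccc(CCl)c3)c2n1` has not yet been measured. It differs from compound 1 in one place: amino in place of chloro on an aromatic carbon. Within the data shown here, no pair of measured compounds differing in a single place is available, so this change has no direct precedent here. The expectation for compound 4 in this assay is a step from compound 1 of about a 1.3-fold higher number from compound 1 to compound 4 (0.13 log units; within the scatter), a modest move toward a higher number, possibly none beyond the scatter. Compound 4 is therefore estimated at 3200 nM, within a range from 1100 nM to 9500 nM.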

Compound 4, concentration for 50% growth inhibition: 2510 nM
Compound 4: middle estimate off by 1.3-fold (0.11 log units), on the high side; the range from low to high includes it.
By their numbers in this assay, from the lowest: compound 3; then compound 2; then compounds 1 and 4 (each within the scatter of the next).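

In this assay, among these compounds, amino in place of chloro on the aromatic carbon between two ring nitrogen atoms gives a 1.1-fold higher number from compound 1 to compound 4 (0.02 log units; within the scatter), the first single-place comparison in this set. Compound 1 and compound 4 cannot be told apart here, so the chloro group at this position is not needed to keep this level of growth inhibition. No measurement at hand bears on this result. On these data alone, whether a methoxy or dimethylamino group on this carbon would also match compound 1 stays open. So does whether amino in place of chloro would read the same on compound 2 or compound 3.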